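This account rests on a few compounds, and the source may have more. Where it says the series, first, only, none or still open, it means among the compounds named here.

Measured compounds:
compound 1, `O=S(=O)(/C=C\c1ncccc1F)c1ccccc1F`: 482 nM in an assay on U2OS cells for activation of nuclear factor erythroid 2-related factor 2 (Homo sapiens), read by beta-arrestin recruitment, with a stated time of 6 h; a higher number here means that more compound is needed for the effect, a lower number that less compound is needed
compound 2, `O=S(=O)(/C=C\c1ncccc1F)c1ccccc1Cl`: 583 nM in this assay
compound 3, `O=S(=O)(/C=C/c1ncccc1F)c1cccc(Cl)c1`: 198 nM in this assay

Compound 1 and compound 2 share one core and differ by chloro in place of fluoro on an aromatic carbon. The step is a 1.2-fold higher number from compound 1 to compound 2 (0.08 log units; within the scatter). Compound 3 carries a different core; the difference between the cores of compound 1 and compound 3 is not broken down here. Compound 3 gives the lowest number of the three, beyond the scatter from both compound 1 and compound 2.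

Compound 4, `O=S(=O)(/C=C/c1ncccc1Cl)c1cccc(Cl)c1`, has not been measured in this assay. It differs from compound 3 by chloro in place of fluoro on an aromatic carbon. This is the same kind of change as from compound 1 to compound 2, not the same one: there the place was on a six-membered aromatic ring of carbon only, ortho to a large group; here it is on a six-membered aromatic ring with one nitrogen, ortho to a large group, two atoms from the ring nitrogen. Within the data shown here, only one measured instance of the change exists, so the expectation rests on it alone: the step of a 1.2-fold higher number from compound 3 to compound 4 (0.08 log units; within the scatter) is expected, close to a 1.2-fold higher number from compound 1 to compound 2 (0.08 log units; within the scatter). Compound 4 is therefore estimated at 240 nM, with a range from 120 nM to 480 nM.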

Compound 4, half-maximal effective concentration: 46 nM
The estimate for compound 4 lay 5.2-fold (0.72 log units) above the measured number, and the stated range ends above it.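

In this assay, chloro in place of fluoro on the six-membered aromatic ring with one nitrogen gives a 4.3-fold lower number from compound 3 to compound 4 (0.63 log units; beyond the scatter). The step measured on one core does not carry over as a fixed increment to the other: the same change on two cores in this assay, a 1.2-fold higher number (0.08 log units; within the scatter) from compound 1 to compound 2 and a 4.3-fold lower number (0.63 log units; beyond the scatter) from compound 3 to compound 4, 5.2-fold (0.72 log units) apart, beyond the scatter of two such steps. These two instances do not show what sets the steps apart, as the change sits on a different ring in each and the cores also differ.

On these data alone, it remains open whether chloro in place of fluoro on the ring with one nitrogen would give a similar step on the core of compound 1. Also open, as far as these compounds go, is how other groups at that place, such as methyl, methoxy or nitrile, compare with the chloro of compound 4.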